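Series notes: from compound 2 toward compound 4

The source may hold more compounds than are shown below. What is called first, only, known or untested is meant among the compounds shown, and "the series" means these compounds.

Three members of the series have been measured in an assay on HEK293 cells for inhibition of Steryl-sulfatase (Homo sapiens), tested at 1 uM; on this read-out higher numbers stand for a stronger effect at the one concentration tested and lower numbers for a weaker effect. Compound 1 `CN(C)CCN(CCN(C)C)c1ccc(C(=O)N2CCc3ccc(OS(N)(=O)=O)cc3C2)cc1` gives 15.9%, compound 3 `CCCN(CCC)c1ccc(C(=O)N2CCc3ccc(OS(N)(=O)=O)cc3C2)cc1` gives 84.7%, and compound 2 `CN(C)CCCN(Cc1ccccc1)c1ccc(C(=O)N2CCc3ccc(OS(N)(=O)=O)cc3C2)cc1` gives 61.6%, which places compound 2 second of the three, closest to compound 3 and well clear of compound 1. For the measured compounds named here, the only single-point step on record, a number 68.8 percentage points higher from compound 1 to compound 3 (beyond the scatter), shows that removing dimethylamino-bearing chains from the aromatic nitrogen raises inhibition strongly. Compound 4 `NS(=O)(=O)Oc1ccc2c(c1)CN(C(=O)c1ccc(N(Cc3ccccc3)Cc3ccco3)cc1)CC2` takes this direction: furan-2-yl in place of 2-(dimethylamino)ethyl on a saturated chain carbon bound to a nitrogen on an aromatic ring. On that basis an upward step is expected, a number 18.4 percentage points higher from compound 2 to compound 4 (beyond the scatter), though smaller than the recorded one since only one chain is lost. Compound 4 is therefore estimated at 80%, within 65% to 92%.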

Compound 4, a percentage reported as inhibition, at one concentration (the size of the read-out at that concentration, not a potency): 98.2%
Beside the measured number, compound 4's estimate is 18.2 percentage points below it; measured number outside the range, above it.
By their numbers in this assay, from the lowest: compound 1; then compound 2; then compound 3; then compound 4.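

At the saturated chain carbon bound to a nitrogen on an aromatic ring, furan-2-yl in place of 2-(dimethylamino)ethyl gives a number 36.6 percentage points higher from compound 2 to compound 4 (beyond the scatter) in this assay. Unlike the earlier step, this change leaves the benzyl group in place and swaps groups of matching heavy-atom count, so a single replacement is enough for a large rise. Nothing measured here explains the step.

On these data alone, whether the rise follows the loss of the dimethylamino amine or the entry of the furan ring stays open. Thiophen-2-yl or 2-methoxyethyl at this place would separate the two.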